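The compounds below may be only part of what the source reports. "The series", "measured", "known", "first", "only" and "open" are said of these compounds alone.

In an assay on mitochondria from L6 cells (Rattus norvegicus) for activation, with a stated time of 90 min (on this read-out higher numbers stand for an effect only at larger amounts of compound and lower numbers for an effect already at smaller amounts), compound 3 `Fc1ccccc1Nc1nc2nonc2nc1NCCC(F)(F)F` gives > 100000 nM, which is a limit of the assay rather than a number. Compound 1 `COc1ccc(Nc2nc3nonc3nc2Nc2ccc(OC)cc2)cc1` likewise reaches only > 100000 nM, again a limit. Compound 2 `FC(F)(F)Oc1ccc(Nc2nc3nonc3nc2Nc2ccc(OC(F)(F)F)cc2)cc1` gives < 5000 nM, a limit on the opposite side. Two of the three values therefore sit at the limit of > 100000 nM in this assay, at which 2 of the 3 values shown sit, and one at the limit of < 5000 nM in this assay, at which 1 of the 3 values shown sits, and compound 3 belongs to the pair showing no effect within the tested range. Compound 4 `COc1cccc(Nc2nc3nonc3nc2Nc2ccccc2F)c1` carries 3-methoxyphenyl in place of 3,3,3-trifluoropropyl on a nitrogen on an aromatic ring. Going by the values given here, no measured pair shows this kind of change, so no step size can be read from the data. Because compound 2, which also carries two aryl groups, sits at the limit of < 5000 nM in this assay, at which 1 of the 3 values shown sits, a step of an at least 3.3-fold lower number from compound 3 to compound 4 (0.52 log units; beyond the scatter) toward an effect at smaller amounts is expected in this assay. Compound 4 is estimated at 30000 nM, within a range from 5000 nM to 100000 nM.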

Compound 4, half-maximal effective concentration: 830 nM
For compound 4 the middle estimate is 36-fold (1.56 log units) above the measured one, outside the stated range (below it).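

Putting 3-methoxyphenyl in place of 3,3,3-trifluoropropyl on a nitrogen on an aromatic ring gives an at least 120-fold lower number from compound 3 to compound 4 (2.08 log units; beyond the scatter) in this assay. Going by these compounds alone, no earlier pair could show it, but the group at this position clearly matters, and compound 4 is the first compound here with a true number rather than a limit. The real size of the step remains unknown, since the value for compound 3 is a limit: the limit of > 100000 nM in this assay, at which 2 of the 4 values shown sit.

Going by these compounds, it remains open whether the ring or its methoxy group drives the change. A plain phenyl ring or a longer alkyl chain at this position could help separate the two.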